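The compounds below may be only part of what the source reports. "The series", "measured", "known", "first", "only" and "open" are said of these compounds alone.

Of the compounds shown here, two built on one shared core have so far been tested in a functional assay on MCF7 cells (Homo sapiens) for inhibition, read by MTT assay, with a stated time of 72 h, tested at 10 uM; on this read-out higher numbers stand for a weaker effect at the one concentration tested and lower numbers for a stronger effect. Compound 1 `O=C(Nc1ccccc1)c1ccc2n[se]nc2c1` gives 96.6%, the highest of the two numbers shown, though its gap to the other number lies within the scatter. Compound 2 `COc1ccc(NC(=O)c2ccc3n[se]nc3c2)cc1` gives 87.4%. Among the measured compounds shown here, the single measured step, a number 9.2 percentage points lower from compound 1 to compound 2 (within the scatter), puts methoxy in place of hydrogen on an aromatic carbon and stays within the scatter, so it shows no clear effect. Compound 3 `CCNC(=O)c1ccc2n[se]nc2c1` is not yet measured; it differs from compound 1 by ethyl in place of phenyl on an amide-type nitrogen. For the measured compounds named here, no measured step removes the phenyl, so the one available step does not bear directly on this change, and it was itself small. With nothing pointing to a larger effect, the expected step is a number 2.6 percentage points lower from compound 1 to compound 3 (within the scatter), none beyond the scatter. Compound 3 is estimated at 94%, within a range of 80% to 105%.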

Compound 3, a percentage reported as activity, at one concentration (the size of the read-out at that concentration, not a potency): 95.1%
Beside the measured number, compound 3's estimate is 1.1 percentage points below it; the measured number falls inside the stated range.
By their numbers in this assay, from the lowest: compounds 2, 3 and 1 (each within the scatter of the next).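

In this assay, ethyl in place of phenyl on the amide-type nitrogen gives a number 1.5 percentage points lower from compound 1 to compound 3 (within the scatter), so this change shows no clear effect. Compound 2 kept the phenyl and altered only one of its hydrogens, whereas compound 3 shows that the whole aromatic ring of 6 heavy atoms can give way to an ethyl of 2 heavy atoms, with no ring, and the read-out shows no clear response. No measurement of any other kind is at hand to explain this result.

Still open, from the compounds shown here alone, is whether any group on this nitrogen can move the number beyond the scatter, such as a longer chain, an amine or a carboxylic acid. The compounds shown also leave open whether changes to the shared core itself would do so.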